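The source may report more compounds than this note shows. Statements on the series, on what has been measured and on what is new or still open speak of the compounds shown alone.

Three measured compounds share one core and differ only in the aromatic group attached to it. Compound 1 `N#Cc1ccccc1-c1cnc(C(=O)CCCCCCc2ccccc2)o1` gives 130 nM in an assay (Rattus norvegicus) for inhibition of Fatty-acid amide hydrolase 1 (Homo sapiens); on this read-out lower numbers stand for stronger inhibition and higher numbers for weaker inhibition; compound 2 `N#Cc1cccc(-c2cnc(C(=O)CCCCCCc3ccccc3)o2)c1` gives 15 nM in this assay; compound 3 `COc1ccc(-c2cnc(C(=O)CCCCCCc3ccccc3)o2)cc1` gives 100 nM in this assay. On these numbers compound 3 stands second highest, close to compound 1 and far from compound 2, as the step of a 6.7-fold higher number from compound 2 to compound 3 (0.82 log units; beyond the scatter) shows.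

Compound 4 `Cc1ccnc(-c2cnc(C(=O)CCCCCCc3ccccc3)o2)c1` differs from compound 3 in one place: 4-methylpyridin-2-yl in place of 4-methoxyphenyl on an aromatic carbon. Among the measured compounds shown here, no measured step swaps a carbon-only ring for a ring with a nitrogen, so the closest guides are the aryl changes already seen, namely a 1.3-fold lower number from compound 1 to compound 3 (0.11 log units; within the scatter), which stayed within the scatter, and an 8.7-fold lower number from compound 1 to compound 2 (0.94 log units; beyond the scatter), a modest shift. A change of similar or smaller size seems plausible here, and no direction is clearly signalled.

Compound 4 is therefore expected to land near compound 3, with the step of a 1.7-fold lower number from compound 3 to compound 4 (0.22 log units; within the scatter) estimated at 60 nM, within a range from 15 nM to 250 nM in this assay.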

Compound 4, inhibition constant: 0.6 nM
Estimate against measurement, compound 4: 100-fold (2.00 log units) above; measured number below the stated range.
By their numbers in this assay, from the lowest: compound 4; then compound 2; then compounds 3 and 1 (each within the scatter of the next).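

Placing 4-methylpyridin-2-yl on this aromatic carbon, next to the ring oxygen, changes the number far more than any swap among the three carbon-only rings. In this assay the new step is large (a 170-fold lower number from compound 3 to compound 4 (2.22 log units; beyond the scatter)), whereas the biggest earlier step was only modest (an 8.7-fold lower number from compound 1 to compound 2 (0.94 log units; beyond the scatter)). Compound 4 also stands beyond the scatter from both cyanophenyl compounds (a 25-fold lower number from compound 2 to compound 4 (1.40 log units; beyond the scatter); a 220-fold lower number from compound 1 to compound 4 (2.34 log units; beyond the scatter)), making it the strongest inhibitor of the four, and no measurement is available to explain this gain.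

Compound 3 and compound 4 differ in both the ring and its substituent, so the contributions of the ring nitrogen and the methyl cannot be separated. A plain pyridin-2-yl or a 4-methoxypyridin-2-yl group would be needed to tell them apart.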